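Cytotoxicity notes: a carbamoyl-extended amide side chain

A few compounds are considered here, and "the series" means these few. Any claim that something is new, unique, unknown or untested is made for them only; others in the source may bear on it.

Among the compounds with values here, compound 1 `Cc1cc(C)cc(S(=O)(=O)c2c(C(=O)NCc3ccccc3O)[nH]c3ccc(Cl)cc23)c1` in an ADME assay on MT4 cells (Homo sapiens) for cytotoxicity, read by MTT assay (a lower number here means that less compound is tolerated, a higher number that more compound is tolerated), gives 23800 nM, which puts it second highest of the three numbers so far. Compound 2 `Cc1cc(C)cc(S(=O)(=O)c2c(C(=O)NCc3ccccc3N)[nH]c3ccc(Cl)cc23)c1` gives 46200 nM in this assay, and compound 3 `Cc1cc(C)cc(S(=O)(=O)c2c(C(=O)NC(C)c3cccc(O)c3)[nH]c3ccc(Cl)cc23)c1` gives 16000 nM. Within the data shown here, the step of a 1.9-fold higher number from compound 1 to compound 2 (0.29 log units; within the scatter) and the step of a 1.5-fold lower number from compound 1 to compound 3 (0.17 log units; within the scatter) both fall inside the scatter, so compound 1 is not separated from either neighbour; only the step of a 2.9-fold lower number from compound 2 to compound 3 (0.46 log units; beyond the scatter) is a modest one.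

Compound 4 `Cc1cc(C)cc(S(=O)(=O)c2c(C(=O)NCC(=O)NCc3cccc(O)c3)[nH]c3ccc(Cl)cc23)c1` differs from compound 1 in one place: (3-hydroxybenzyl)carbamoyl in place of 2-hydroxyphenyl on a saturated chain carbon bound to an amide-type nitrogen. Among the measured compounds shown here, no measured step covers such an insertion on the chain carbon. The nearest point of comparison is compound 3, whose hydroxyphenyl variant gave the step of a 1.5-fold lower number from compound 1 to compound 3 (0.17 log units; within the scatter), which stays within the scatter; the change from compound 2 to compound 3 also concerns the aromatic substituent, not the chain. For compound 4 the expected step in this assay is therefore a 1.1-fold higher number from compound 1 to compound 4 (0.02 log units; within the scatter), not beyond the scatter. Compound 4 is estimated at 25000 nM, with a range from 10000 nM to 60000 nM.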

Compound 4, half-maximal cytotoxic concentration: > 47500 nM
Compound 4 was reported as a limit; the forecaster's own chance of this, stated with the estimate: 10%; at least 1.9-fold (0.27 log units) between middle value and limit.
By their numbers in this assay, from the lowest: compounds 3, 1 and 2 (each within the scatter of the next, the first and the last beyond it). At a limit, above all of these: compound 4.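

Compound 4 is reported in this assay only as a limit: the limit of > 47500 nM in this assay, at which 1 of the 4 values shown sits. With (3-hydroxybenzyl)carbamoyl in place of 2-hydroxyphenyl on a saturated chain carbon bound to an amide-type nitrogen, the readings are an at least 1.9-fold higher number from compound 1 to compound 4 (0.30 log units; that floor lies within the scatter) and an at least 1.0-fold higher number from compound 2 to compound 4 (0.01 log units; that floor lies within the scatter), so these floors do not separate compound 4 from compound 1 or compound 2, while an at least 2.9-fold higher number from compound 3 to compound 4 (0.47 log units; beyond the scatter) clears the scatter even at its floor. Within the data shown here, this larger side chain therefore brings no lowering of the number at this position, something the smaller side chains of the earlier compounds could not show.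

Going by these compounds, how far the number for compound 4 lies past its limit stays open. Also open, on these data alone, is whether an amine or a carboxylic acid in place of the hydroxy on the (3-hydroxybenzyl)carbamoyl group would keep the number at this level.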